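Reduced imine analogue of a serine-derived tetradecyl amide

A few compounds are considered here, and "the series" means these few. Any claim that something is new, unique, unknown or untested is made for them only; others in the source may bear on it.

Of the compounds shown here, three sharing a core with a tetradecyl amide have been measured in a functional assay on cells (Homo sapiens) for cytotoxicity, read by MTT assay, with a stated time of 24 h; on this read-out lower numbers stand for stronger inhibition and higher numbers for weaker inhibition. Compound 1, `CCCCCCCCCCCCCCNC(=O)[C@H](CO)/N=C/c1ccccc1OC`, gives 12500 nM, the lowest number of the three. Compound 2, `CCCCCCCCCCCCCCNC(=O)[C@H](CO)/N=C/c1ccc(C)cc1`, gives 102000 nM, and compound 3, `CCCCCCCCCCCCCCNC(=O)[C@H](CO)/N=C/c1cccc(OC)c1`, gives 31300 nM. The steps among them all change only the aromatic ring on the carbon with a double bond to nitrogen: an 8.2-fold higher number from compound 1 to compound 2 (0.91 log units; beyond the scatter), a 2.5-fold higher number from compound 1 to compound 3 (0.40 log units; beyond the scatter) and a 3.3-fold lower number from compound 2 to compound 3 (0.51 log units; beyond the scatter).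

Compound 4, `CCCCCCCCCCCCCCNC(=O)[C@H](CO)NCc1ccccc1O`, differs from compound 1 as follows: a group of 9 heavy atoms (7 carbon, 1 nitrogen, 1 oxygen; one six-membered aromatic ring of carbon only) in place of a group of 10 heavy atoms (8 carbon, 1 nitrogen, 1 oxygen; one six-membered aromatic ring of carbon only), on a saturated chain carbon bound to a carbonyl carbon and a saturated chain carbon. Within the data shown here, none of the measured steps bears directly on this change, since each of them alters the aromatic ring while keeping the double bond to nitrogen, whereas here the double bond is lost and a (2-hydroxybenzyl)amino group enters. Among the measured compounds shown here, the measured steps show only that changes to this part of the molecule move the number by modest amounts, and nothing points to a large shift in either direction.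

Compound 4 is therefore expected to lie close to compound 1, with a 1.6-fold higher number from compound 1 to compound 4 (0.20 log units; within the scatter) as the estimated step, and its estimated value in this assay is 20000 nM, within a range from 5000 nM to 80000 nM.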

Compound 4, half-maximal inhibitory concentration: 75300 nM
The estimate for compound 4 lay 3.8-fold (0.58 log units) below the measured number, and the stated range covers the measured number.
By their numbers in this assay, from the lowest: compound 1; then compound 3; then compounds 4 and 2 (each within the scatter of the next).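

In this assay, the first change shown at this saturated chain carbon that removes the double bond to nitrogen, rather than only altering the aromatic ring, gives a 6.0-fold higher number from compound 1 to compound 4 (0.78 log units; beyond the scatter) and a 2.4-fold higher number from compound 3 to compound 4 (0.38 log units; beyond the scatter) as well, so compound 1 and compound 3 both keep lower numbers than the (2-hydroxybenzyl)amino compound. Against the remaining compound the result is a 1.4-fold lower number from compound 2 to compound 4 (0.13 log units; within the scatter) and places this new group level with the 4-methylphenyl imine, so a change in the link and the ring together can cost about as much as the ring changes alone did. Nothing available here explains this step.

Because the double bond goes and a hydroxyl replaces the methoxy in the same step, the compounds shown cannot say which of these two differences carries the higher number, and a saturated amine keeping the 2-methoxyphenyl ring of compound 1 would separate them. They also leave open how a tertiary N-methyl amine at this carbon, or a carboxylic acid or a shorter chain in place of the tetradecyl amide, would read in this assay on this core.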